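Piperazine benzyl replacements: cytotoxicity limits in the series

The source may report more compounds than this note shows. Statements on the series, on what has been measured and on what is new or still open speak of the compounds shown alone.

Measured compounds:
- compound 1 `CC(=O)N1CCC(C(=O)N(CCCN2CCN(Cc3ccc(S(C)(=O)=O)cc3)CC2)c2ccc(C)c(Cl)c2)CC1` — an ADME assay (Homo sapiens) for cytotoxicity (a lower number here means that less compound is tolerated, a higher number that more compound is tolerated), gives > 49200 nM for compound 1, a limit of the assay.
- compound 2 `CC(=O)N1CCC(C(=O)N(CCCN2CCN(Cc3cccnc3)CC2)c2ccc(C)c(Cl)c2)CC1` — in this assay compound 2 gives > 56700 nM, likewise a limit.
- compound 3 `CC(=O)N1CCC(C(=O)N(CCCN2CCN(Cc3cnc(Cl)s3)CC2)c2ccc(C)c(Cl)c2)CC1` — in this assay compound 3 gives > 52300 nM, again a limit.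

Compound 3 therefore stands at a limit only, and the two other values sit at limits as well the limit of > 49200 nM in this assay, at which 1 of the 3 values shown sits, the limit of > 52300 nM in this assay, at which 1 of the 3 values shown sits (the limit of > 56700 nM in this assay, at which 1 of the 3 values shown sits). The steps a step that the two limits leave unreadable from compound 1 to compound 2, a step that the two limits leave unreadable from compound 1 to compound 3 and a step that the two limits leave unreadable from compound 2 to compound 3 are all left unreadable by the limits, so nothing about the size of any change on this position is known from the measured set.

Compound 4 `CC(=O)N1CCC(C(=O)N(CCCN2CCN(Cc3ccc(C#N)cc3)CC2)c2ccc(C)c(Cl)c2)CC1` carries the change (4-cyanophenyl in place of 2-chloro-1,3-thiazol-5-yl on a saturated chain carbon bound to an amine nitrogen in a ring). The three measured steps bear on this position but give no readable size, so no step beyond the scatter is expected in this assay; the estimated step is a step that the limit leaves unreadable from compound 3 to compound 4. Compound 4 is expected to give 60000 nM in this assay, within 30000 nM to 200000 nM, most likely again reported as a limit.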

Compound 4, half-maximal cytotoxic concentration: > 100000 nM
Compound 4 ended at the assay's limit; the forecaster's own chance of this, stated with the estimate: 80%; middle value at least 1.6-fold (0.22 log units) from the limit.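

In this assay compound 4 gives > 100000 nM, a limit of the assay. With compound 1, compound 2 and compound 3 also at limits, none of the steps to compound 4 can be read. The compounds shown leave open the size of any change at this position, on a saturated chain carbon bound to an amine nitrogen in a ring.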